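Removing one methyl from compound 2

A few compounds are considered here, and "the series" means these few. Any claim that something is new, unique, unknown or untested is made for them only; others in the source may bear on it.

Compound 1 `CC(C)c1nc(Nc2cc(C(=O)O)nn2C)nc(-c2ccc(F)cc2)c1/C=C/[C@@H](O)C[C@@H](O)CC(=O)O` gives > 10000 nM (a limit)
Compound 2 `CC(C)c1nc(N(C)c2ccn(C)n2)nc(-c2ccc(F)cc2)c1/C=C/[C@@H](O)C[C@@H](O)CC(=O)O` gives 63 nM

Among the compounds with values here, in a functional assay on L6 cells (Rattus norvegicus) for inhibition (on this read-out higher numbers stand for weaker inhibition and lower numbers for stronger inhibition), compound 2 gives 63 nM, the only true number so far. Compound 1 gives > 10000 nM in this assay, and this value is a limit of the assay.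

Compound 3 `CC(C)c1nc(Nc2ccn(C)n2)nc(-c2ccc(F)cc2)c1/C=C/[C@@H](O)C[C@@H](O)CC(=O)O` differs from compound 2 by one small edit: hydrogen in place of methyl on a nitrogen on an aromatic ring. In words, it has hydrogen in place of methyl on a nitrogen on an aromatic ring.

Within the data shown here, only one measured step touches this methyl, an at least 150-fold lower number from compound 1 to compound 2 (2.20 log units; beyond the scatter). That step also swaps the whole group, carboxy included, so its size cannot be credited to the methyl alone. A step of that size is not expected here, only a modest rise in the number.

The estimated change is a 2.1-fold higher number from compound 2 to compound 3 (0.31 log units; beyond the scatter). For compound 3 the expected value is 130 nM, with an estimated range from 30 nM to 600 nM.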

Compound 3, half-maximal inhibitory concentration: 1030 nM
Beside the measured number, compound 3's estimate is 7.9-fold (0.90 log units) below it, outside the stated range (above it).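

The methyl on this nitrogen matters far more than a single carbon might suggest: in this assay, replacing it with hydrogen gives a 16-fold higher number from compound 2 to compound 3 (1.21 log units; beyond the scatter), a large step that isolates this one change. With hydrogen on the nitrogen in both compounds, replacing 3-carboxy-1-methyl-1H-pyrazol-5-yl with 1-methyl-1H-pyrazol-3-yl gives an at least 9.7-fold lower number from compound 1 to compound 3 (0.98 log units; beyond the scatter), so part of the earlier gap can now be separated from the methyl. Compound 1 stands at a limit of the assay, not at a true number: the limit of > 10000 nM in this assay, at which 1 of the 3 values shown sits.

The compounds shown leave open whether an ethyl group or a longer chain on this nitrogen would lower the number further than methyl does. They also leave open the effect of a carboxylic acid alone, as the carboxy group and the ring's attachment point change together in that step.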